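Swapping a Methylphenyl for a Methylthiophene in a Cytotoxicity Series

The source may report more compounds than this note shows. Statements on the series, on what has been measured and on what is new or still open speak of the compounds shown alone.

Compound 1 `Cc1ccc(/C=C2/S/C(=N/c3ccccc3)N(Cc3ccncc3)C2=O)cc1` was tested in an ADME assay on HEK293 cells (Homo sapiens) for cytotoxicity, read by MTT assay, with a stated time of 48 h (a higher number here means a weaker inhibitor, a lower number a stronger inhibitor), where compound 1 gives 49500 nM. Compound 2 `O=C1/C(=C\c2ccc(Cl)cc2)S/C(=N/c2ccccc2)N1Cc1ccncc1` gives 42300 nM and compound 3 `COc1cc(/C=C2/S/C(=N/c3ccccc3)N(Cc3ccncc3)C2=O)ccc1O` gives 67400 nM. Among these three numbers compound 1 stands second highest. The steps of a 1.2-fold lower number from compound 1 to compound 2 (0.07 log units; within the scatter) and a 1.4-fold higher number from compound 1 to compound 3 (0.13 log units; within the scatter) both stay within the scatter, and so does a 1.6-fold higher number from compound 2 to compound 3 (0.20 log units; within the scatter). Compound 4 `Cc1ccc(/C=C2/S/C(=N/c3ccccc3)N(Cc3ccncc3)C2=O)s1` has not yet been measured. It differs from compound 1 in one place: 5-methylthiophen-2-yl in place of 4-methylphenyl on a double-bonded chain carbon bound to a double-bonded ring carbon. All three measured steps change the group at this same place, and none of them moved the number beyond the scatter, so for compound 4 the step of a 1.0-fold higher number from compound 1 to compound 4 (0.00 log units; within the scatter) is expected to stay within the scatter as well. Compound 4 is estimated at 50000 nM, in a range from 25000 nM to 100000 nM.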

Compound 4, half-maximal inhibitory concentration: 146000 nM
For compound 4 the middle estimate is 2.9-fold (0.47 log units) below the measured one; measured number outside the range, above it.
By their numbers in this assay, from the lowest: compounds 2, 1 and 3 (each within the scatter of the next); then compound 4.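

In this assay, among these compounds, 5-methylthiophen-2-yl is the first group at this position to move the number beyond the scatter, giving a 2.9-fold higher number from compound 1 to compound 4 (0.47 log units; beyond the scatter), a 2.2-fold higher number from compound 3 to compound 4 (0.34 log units; beyond the scatter) and a 3.5-fold higher number from compound 2 to compound 4 (0.54 log units; beyond the scatter). The position therefore responds to a change of ring, from six-membered to five-membered with a hetero atom, more than the three substituted phenyl groups suggested. No measurement here gives a reason for this shift. From the compounds shown here alone, it remains open whether the sulfur, the ring size or the methyl matters most. A thiophen-2-yl without the methyl, or a furan-2-yl, would help separate these.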